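The compounds below may be only part of what the source reports. "The series", "measured", "known", "first", "only" and "open" are said of these compounds alone.

Measured so far:
compound 1 `CCN(CC)S(=O)(=O)c1ccc(S(=O)(=O)N2CCC[C@@H](C(=O)N[C@H]3CC[C@H](OC)CC3)C2)cc1`, 2000 nM
compound 2 `CCC(CC)S(=O)(=O)c1ccc(S(=O)(=O)N2CCC[C@@H](C(=O)N3CCC(F)(F)CC3)C2)cc1`, 40 nM

In a functional assay on BXPC-3 cells (Homo sapiens) for inhibition, read by MTT assay, with a stated time of 7 days (a lower number here means a stronger inhibitor, a higher number a weaker inhibitor), compound 1 gives 2000 nM, the highest of the two numbers, while compound 2 gives 40 nM; the two structures differ in more than one place, so the gap is not traced to a single change. Compound 3 `CCN(CC)S(=O)(=O)c1ccc(S(=O)(=O)N2CCC[C@@H](C(=O)N[C@@H]3CCOC3)C2)cc1` differs from compound 1 only at the amide-type nitrogen: oxolan-3-yl in place of 4-methoxycyclohexyl on an amide-type nitrogen. For the measured compounds named here, with no single-change step measured, the step from compound 1 to compound 3 is expected to stay within the usual scatter, a 1.3-fold higher number from compound 1 to compound 3 (0.10 log units; within the scatter). Compound 3 is therefore estimated at 2500 nM, with a range from 600 nM to 10000 nM.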

Compound 3, half-maximal inhibitory concentration: 2270 nM
For compound 3 the middle estimate is 1.1-fold (0.04 log units) above the measured one; low and high end bracket the measured number.
By their numbers in this assay, from the lowest: compound 2; then compounds 1 and 3 (each within the scatter of the next).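

In this assay, putting oxolan-3-yl in place of 4-methoxycyclohexyl on the amide-type nitrogen gives a 1.1-fold higher number from compound 1 to compound 3 (0.05 log units; within the scatter). This first single-change step shows that, on this core, the six-membered carbon ring and its methoxy group can give way to a five-membered ring with one hetero atom without a reading beyond the scatter. No available evidence accounts for this result. On these data alone, it remains open whether an open-chain group such as 2-methoxyethyl, or an amine-bearing ring such as piperidin-4-yl, would read differently on this nitrogen.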